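Cyclohexyl for fluorobenzyl on compound 1: notes before measurement

The source may hold more compounds than are shown below. What is called first, only, known or untested is meant among the compounds shown, and "the series" means these compounds.

Measured so far:
Compound 1 `O=c1cc(NCc2cccc(F)c2)sc2c([N+](=O)[O-])cc(C(F)(F)F)cc12`: in an ADME assay on Vero cells (Chlorocebus sabaeus) for cytotoxicity, read by MTT assay, with a stated time of 48 h (a higher number here means a weaker inhibitor, a lower number a stronger inhibitor), compound 1 gives the limit > 64 ug/mL.
Compound 2 `O=c1nc(NCC2CCCCC2)oc2c([N+](=O)[O-])cc(C(F)(F)F)cc12`: in this assay compound 2 gives 29.7 ug/mL.
Compound 3 `COc1ccc(CNc2cc(=O)c3cc(C(F)(F)F)cc([N+](=O)[O-])c3s2)cc1OC`: in this assay compound 3 gives the limit > 64 ug/mL.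

Compound 1 therefore stands at a limit, not at a number. The step that the two limits leave unreadable from compound 1 to compound 3 cannot be read because of the limit of > 64 ug/mL in this assay, at which 2 of the 3 values shown sit.

Compound 4 `O=c1cc(NC2CCCCC2)sc2c([N+](=O)[O-])cc(C(F)(F)F)cc12` differs from compound 1 by cyclohexyl in place of 3-fluorobenzyl on a nitrogen on an aromatic ring. Among the compounds with values here, no measured step covers this change; compound 2, which carries a saturated ring on a different core, gives a number rather than a limit. The expectation for the step is an at least 1.1-fold lower number from compound 1 to compound 4 (0.06 log units; that floor lies within the scatter), with a fair chance that only a limit is reported again. Compound 4 is estimated at 55 ug/mL, within 25 ug/mL to 120 ug/mL.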

Compound 4, half-maximal inhibitory concentration: > 64 ug/mL
Compound 4: only a limit was reported; the forecaster's own chance of this, stated with the estimate: 55%; middle value at least 1.1-fold (0.06 log units) from the limit.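

In this assay compound 4 gives only a limit, > 64 ug/mL, as compound 1 does, so no step between compound 1 and compound 4 can be read: the limit of > 64 ug/mL in this assay, at which 3 of the 4 values shown sit.

As far as these compounds go, whether cyclohexyl in place of 3-fluorobenzyl shifts the value at all stays open, as does any actual number for either compound.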